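Swapping the sulfonyl cap on an acylsulfonamide

The source may report more compounds than this note shows. Statements on the series, on what has been measured and on what is new or still open speak of the compounds shown alone.

Compound 1 `COc1ccc(-c2ccc(OCc3cc(C(=O)NS(=O)(=O)c4cccs4)oc3C)cc2)cc1` shows the lower of the two recorded numbers in an assay on cells for displacement of a labelled ligand from prostaglandin E2 receptor EP4 subtype (Homo sapiens), read by scintillation counting (on this read-out lower numbers stand for stronger inhibition and higher numbers for weaker inhibition), giving 3.6 nM. In this assay compound 2 `Cc1oc(CC(=O)O)cc1COc1ccc(-c2ccccc2)cc1` gives 80 nM, a gap beyond the usual scatter. Compound 3 `COc1ccc(-c2ccc(OCc3cc(C(=O)NS(=O)(=O)Cc4ccccc4)oc3C)cc2)cc1` keeps the core of compound 1 and alters only the sulfonyl cap: benzyl in place of thiophen-2-yl on a sulfonyl sulfur. Among the compounds with values here, no measured pair shows this exact change, so the expected step is small, within or close to the scatter, leaning toward a slightly higher number: a 1.7-fold higher number from compound 1 to compound 3 (0.22 log units; within the scatter). Compound 3 is therefore estimated at 6 nM, within 2 nM to 20 nM.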

Compound 3, inhibition constant: 3 nM
Compound 3: the middle estimate sits 2.0-fold (0.30 log units) above what was measured, and the stated range covers the measured number.
By their numbers in this assay, from the lowest: compounds 3 and 1 (each within the scatter of the next); then compound 2.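

In this assay, benzyl in place of thiophen-2-yl on a sulfonyl sulfur gives a 1.2-fold lower number from compound 1 to compound 3 (0.08 log units; within the scatter) and so leaves the two compounds indistinguishable. This place on the acylsulfonamide therefore accepts a six-membered aromatic ring of carbon only as readily as the sulfur-containing five-membered one, so thiophen-2-yl is not required here. Nothing available explains why the two caps read alike.

Still open, going by these compounds, is whether a cap without any ring, such as methyl, would hold up equally well. The same question applies to a benzyl cap carrying an amine.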